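The compounds below may be only part of what the source reports. "The series", "measured", "known", "first", "only" and "open" are said of these compounds alone.

Three compounds of the shared core carry numbers in a functional assay on HeLa cells (Homo sapiens) for cytotoxicity, read by MTT assay, with a stated time of 72 h, tested at 3 uM; a higher number here means more inhibition of growth at the concentration tested, a lower number less inhibition of growth. Compound 1 `N/C(=N\NC(=S)N1CCOCC1)c1ccccn1` gives 40%, compound 2 `Cc1ccnc(/C(N)=N/NC(=S)N2CCSCC2)c1` gives 40.4% and compound 3 `Cc1cccc(/C(N)=N/NC(=S)N2CCCCCC2)n1` gives 63.6%. Compound 2 stands second highest of the three: the numbers of compound 1 and compound 2 lie within the scatter of each other, while compound 3 sits beyond the scatter above compound 2. Compound 4 `Cc1ccnc(/C(N)=N/NC(=S)N2CCCC2)c1` is not yet measured and differs from compound 2 in one place: pyrrolidin-1-yl in place of thiomorpholin-4-yl on a thiocarbonyl carbon. Among the compounds with values here, no measured pair isolates this change, so its size is open. The step expected in this assay is a number 1.6 percentage points higher from compound 2 to compound 4 (within the scatter), none beyond the scatter. Compound 4 is therefore estimated at 42%, within 25% to 62%.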

Compound 4, percent growth inhibition at one concentration: 52.1%
Estimate against measurement, compound 4: 10.1 percentage points below; measured number inside the range.
By their numbers in this assay, from the lowest: compounds 1 and 2 (each within the scatter of the next); then compound 4; then compound 3.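

In this assay, within the data shown here, pyrrolidin-1-yl in place of thiomorpholin-4-yl on a thiocarbonyl carbon gives a number 11.7 percentage points higher from compound 2 to compound 4 (beyond the scatter) and so supplies the first single-place comparison. This position therefore responds to a change of ring, which compound 1, compound 2 and compound 3 could not show, as they differ from one another in more than one place. No measurement here bears on the reason for this step. On these data alone, the swap changes ring size and removes the sulfur together, so the share of each remains open. A piperidin-1-yl group at this position would separate the two.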